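Replacing methyl with nitro on compound 1

The compounds below may be only part of what the source reports. "The series", "measured", "known", "first", "only" and "open" are said of these compounds alone.

compound 1 `CCOC(=O)c1cc(/C=C/c2cccc(C)c2)on1`: > 128000 nM
compound 2 `CCOC(=O)c1cc(/C=C/c2cc(F)cc(F)c2)on1`: > 128000 nM

Both values come from an ADME assay on Vero cells (Chlorocebus sabaeus) for cytotoxicity, with a stated time of 72 h; a higher number here means a weaker inhibitor, a lower number a stronger inhibitor. Compound 1 stands at a limit of this assay, > 128000 nM, and not at a number. Compound 2 likewise gives only a limit, > 128000 nM. Among the measured compounds shown here, the shared reading is the limit of > 128000 nM in this assay, at which 2 of the 2 values shown sit, so no measured step is available as a guide.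

Compound 3 `CCOC(=O)c1cc(/C=C/c2cccc([N+](=O)[O-])c2)on1` keeps the core of compound 1 and carries nitro in place of methyl on an aromatic carbon, meta to a large group (nitro in place of methyl on an aromatic carbon). In this assay, only a small step towards lower numbers is expected, and perhaps none beyond the scatter, with the reading most likely staying at the limit. The expected change is an at least 1.1-fold lower number from compound 1 to compound 3 (0.06 log units; that floor lies within the scatter). For compound 3 the estimate is 110000 nM, with an expected range from 50000 nM to 128000 nM.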

Compound 3, half-maximal inhibitory concentration: > 128000 nM
Compound 3 ended at the assay's limit (the forecaster's own chance of this, stated with the estimate: 65%); middle value at least 1.1-fold (0.06 log units) away from the limit.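

The step from compound 1 to compound 3 cannot be read in this assay, as both stand at a limit and not at a number: the limit of > 128000 nM in this assay, at which 3 of the 3 values shown sit. The compounds shown leave open whether any change on the shared core would give a measured number in this test.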